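Methoxy addition to compound 2: working notes

This account rests on a few compounds, and the source may have more. Where it says the series, first, only, none or still open, it means among the compounds named here.

Measured in a functional assay on NCI-H1299 cells (Homo sapiens) for antiproliferative activity, read by fluorescence and resazurin assay, with a stated time of 48 h; a lower number here means a stronger inhibitor, a higher number a weaker inhibitor:
- compound 1 `COc1cc(-c2cn(Cc3ccc(O)c(O)c3)cc2-c2cc(OC)c(OC)c(OC)c2)cc(OC)c1OC`: 29200 nM
- compound 2 `COc1ccc(Cn2cc(-c3ccc(O)c(O)c3)c(-c3ccc(O)c(O)c3)c2)cc1`: 8300 nM

Of these two numbers, compound 2 is the lower at 8300 nM, and compound 1 stands at 29200 nM. The gap between the two lies beyond the scatter. Within the data shown here, no measured pair differs in one place only, so the series offers no direct guide to a single change. Compound 3 `COc1ccc(Cn2cc(-c3ccc(O)c(O)c3)c(-c3ccc(O)c(O)c3)c2)cc1OC` carries methoxy in place of hydrogen on an aromatic carbon, with methoxy in place of hydrogen on an aromatic carbon, turning 4-methoxyphenyl into 3,4-dimethoxyphenyl. In this assay no change beyond the scatter is expected, and the estimated step is a 1.1-fold lower number from compound 2 to compound 3 (0.04 log units; within the scatter). The expected value for compound 3 is 7500 nM, with an estimated range of 3000 nM to 20000 nM.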

Compound 3, half-maximal inhibitory concentration: 10500 nM
For compound 3 the middle estimate is 1.4-fold (0.15 log units) below the measured one, within the range that was stated.
By their numbers in this assay, from the lowest: compounds 2 and 3 (each within the scatter of the next); then compound 1.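

In this assay the move from 4-methoxyphenyl to 3,4-dimethoxyphenyl reads as a 1.3-fold higher number from compound 2 to compound 3 (0.10 log units; within the scatter) and so cannot be told apart from repeat scatter. This aromatic carbon, ortho to a methoxy group, therefore accepts a second methoxy with no measurable effect on the number in this scaffold. No accompanying measurement offers an explanation for this result. Still open, on these data alone, is whether an amine, a carboxylic acid or a longer alkoxy chain at this same carbon would also leave the number within the scatter.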